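The source may hold more compounds than are shown below. What is called first, only, known or untested is meant among the compounds shown, and "the series" means these compounds.

Measured so far in a functional assay on BGC-823 cells (Homo sapiens) for inhibition, read by MTT assay, with a stated time of 72 h; a higher number here means a weaker inhibitor, a lower number a stronger inhibitor
compound 1 `Cc1cc(N2CC[C@@H](C)[C@@H](N(C)c3ncnc4[nH]ccc34)C2)n2nc(SCc3ccccc3Br)nc2n1` gives 81100 nM
compound 2 `Cc1nc2nc(SCc3ccc(Cl)cc3)nn2c(N2CC[C@@H](C)[C@@H](N(C)c3ncnc4[nH]ccc34)C2)c1C` gives > 100000 nM, which is a limit of the assay and not a number

Among the measured compounds shown here, compound 1 therefore holds the only actual number so far. Compound 3 `C=CCSc1nc2nc(C)cc(N3CC[C@@H](C)[C@@H](N(C)c4ncnc5[nH]ccc45)C3)n2n1`, not yet measured, departs from compound 1 in one place: vinyl in place of 2-bromophenyl on a saturated chain carbon bound to a sulfur. Put another way, 2-bromobenzyl gives way to allyl. For the measured compounds named here, no measured pair shows what such a change does in this assay, so no step beyond the usual scatter is expected, in either direction. The expectation starts from compound 1 at 81100 nM as its only anchor. The estimated change is a 1.2-fold lower number from compound 1 to compound 3 (0.06 log units; within the scatter) and is expected to stay small. For compound 3 the estimated value is 70000 nM, with an expected range from 25000 nM to 100000 nM when it is measured.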

Compound 3, half-maximal inhibitory concentration: 40900 nM
Beside the measured number, compound 3's estimate is 1.7-fold (0.23 log units) above it; the range from low to high includes it.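

In this assay, among the compounds shown here, this is the first step that can be read at the saturated chain carbon bound to a sulfur: exchanging 2-bromobenzyl for allyl gives a 2.0-fold lower number from compound 1 to compound 3 (0.30 log units; within the scatter). The change removes the aromatic ring and the bromine, going from 7 heavy atoms to 2 in the exchanged group, yet the step stays within the scatter, so this one pair shows no clear dependence on that ring. Compound 2 gives > 100000 nM, which is a limit of the assay and not a number, so it adds no readable step: the limit of > 100000 nM in this assay, at which 1 of the 3 values shown sits.

The compounds shown leave open whether a simple propyl chain would behave like allyl, or whether a longer chain such as hexyl would move the value beyond the scatter. They also leave open what an amine or a carboxylic acid at the end of the chain on the sulfur would do.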